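The source may hold more compounds than are shown below. What is called first, only, known or untested is meant among the compounds shown, and "the series" means these compounds.

In an ADME assay on WI-38 cells (Homo sapiens) for cytotoxicity, read by MTT assay, with a stated time of 72 h (a lower number here means a stronger inhibitor, a higher number a weaker inhibitor), compound 1 `C#Cc1cccc(NC(=O)CCc2cccc3c2B(O)OC3)c1` gives > 100000 nM, which is a limit of the assay. Within the data shown here, compound 2 `CSc1ccc(-c2cccc(NC(=O)CCc3cccc4c3B(O)OC4)c2)cc1` gives 3800 nM, the only actual number so far. Compound 3 `N#Cc1cccc(-c2cccc(NC(=O)CCc3cccc4c3B(O)OC4)c2)c1` follows from compound 2 by 3-cyanophenyl in place of 4-(methylsulfanyl)phenyl on an aromatic carbon. Among the measured compounds shown here, the one measured step bearing on this is an at least 26-fold lower number from compound 1 to compound 2 (1.42 log units; beyond the scatter), which is large, but it put 4-(methylsulfanyl)phenyl in place of ethynyl, whereas here one six-membered aromatic ring of carbon only replaces another. No change beyond the scatter is therefore expected, and the estimated step is a 1.3-fold higher number from compound 2 to compound 3 (0.12 log units; within the scatter). For compound 3 the expected value is 5000 nM, with an estimated range of 1800 nM to 18000 nM.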

Compound 3, half-maximal inhibitory concentration: 7300 nM
The estimate for compound 3 lay 1.5-fold (0.16 log units) below the measured number, and the stated range covers the measured number.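

In this assay, one six-membered aromatic ring of carbon only can replace another at this position, 3-cyanophenyl for 4-(methylsulfanyl)phenyl, with a 1.9-fold higher number from compound 2 to compound 3 (0.28 log units; within the scatter). The large shift away from ethynyl is thus not tied to 4-(methylsulfanyl)phenyl alone, as 3-cyanophenyl also gives an at least 13-fold lower number from compound 1 to compound 3 (1.13 log units; beyond the scatter). The size of that shift stays open-ended, as compound 1 stands at a limit: the limit of > 100000 nM in this assay, at which 1 of the 3 values shown sits.

On these data alone, whether an aromatic ring is needed here remains open, as does the outcome with a saturated cyclohexyl group. Also open, as far as these compounds go, is how a ring carrying an amine or a carboxylic acid at this place would read.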